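This account rests on a few compounds, and the source may have more. Where it says the series, first, only, none or still open, it means among the compounds named here.

Three compounds have been measured in a physicochemical assay for acid dissociation:

Compound 1 `COc1ccc(F)cc1CNCCCNc1ccnc2cc(CCc3ccccc3)ccc12` gives 9.47.
Compound 2 `COc1ccc(F)cc1CNCCCNc1ccnc2cc(-c3cccc4ccccc34)ccc12` gives 9.47.
Compound 3 `COc1ccc(F)cc1CNCCCNc1ccnc2cc(Cc3cccc(C(F)(F)F)c3)ccc12` gives 9.47.

Compound 3 stands level with compounds 1 and 2 at the digits shown: the step of no change at the digits printed from compound 1 to compound 3 (within the scatter) and the step of no change at the digits printed from compound 2 to compound 3 (within the scatter) are both within the scatter, so no compound among the three can be set apart from the others.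

The next compound is compound 4 `COc1ccc(F)cc1CNCCCNc1ccnc2cc(Oc3ccc(Cl)cc3)ccc12`. Its difference from compound 3 is 4-chlorophenoxy in place of 3-(trifluoromethyl)benzyl on an aromatic carbon.

Among the measured compounds shown here, every measured step so far swaps the group on that same aromatic carbon of the shared core: no change at the digits printed from compound 1 to compound 2 (within the scatter), no change at the digits printed from compound 1 to compound 3 (within the scatter) and no change at the digits printed from compound 2 to compound 3 (within the scatter). None of the three moved the reading beyond the scatter, although the groups swapped differed in size and in what they contain. On that record the step of no change at the digits printed from compound 3 to compound 4 (within the scatter) is expected to show no change beyond the scatter. Compound 4 is therefore estimated at 9.47, with a range from 9.2 to 9.75.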

Compound 4, acid dissociation constant: 9.28
The estimate for compound 4 lay 0.19 log units above the measured number; measured number inside the range.
By their numbers in this assay, from the lowest: compounds 4, 1, 2 and 3 (each within the scatter of the next).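

At this aromatic carbon, this assay now shows digits that are no longer identical, yet all three new steps stay inside the scatter: a number 0.19 log units lower from compound 3 to compound 4 (within the scatter) and a number 0.19 log units lower from compound 2 to compound 4 (within the scatter) and a number 0.19 log units lower from compound 1 to compound 4 (within the scatter) are the steps in question. The entering 4-chlorophenoxy brings an oxygen, a chlorine and a hydrogen-bond acceptor where 3-(trifluoromethyl)benzyl has none of these, and compound 4 still cannot be set apart from the other three compounds. No evidence is available that bears on this small difference in the digits.

All four groups shown at this carbon contain an aromatic ring of carbon only, so it remains open whether an amine or a carboxylic acid here would move the reading beyond the scatter. Every change shown sits at this one carbon, and the compounds leave open which proton the reading belongs to.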